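This account rests on a few compounds, and the source may have more. Where it says the series, first, only, none or still open, it means among the compounds named here.

Working notes on the series. Compound 1 `COc1cccc(N2CCN(C(=O)C(C)N3C(=O)CCC3=O)CC2)c1` and compound 2 `CC(C(=O)N1CCN(c2ccc(Cl)cc2)CC1)N1C(=O)CCC1=O` share one core and differ only in the group on an amine nitrogen in a ring. In a functional assay on the whole organism (strain Swiss) with Mus musculus as the target, in the maximal electroshock model, with a stated time of 0.25 h, at a dose of 300 mg/kg by the intraperitoneal route (a higher number here means a stronger effect of the compound at the dose given, a lower number a weaker effect), compound 1 gives 75%, the lowest of the two numbers in hand, while compound 2 gives 100%. Among the measured compounds shown here, the single measured step, a number 25 percentage points higher from compound 1 to compound 2 (beyond the scatter), concerns 4-chlorophenyl in place of 3-methoxyphenyl and is the only comparison available.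

Compound 3 `CCC(C(=O)N1CCN(c2cccc(OC)c2)CC1)N1C(=O)CCC1=O` is not yet measured. It differs from compound 1 by methyl in place of hydrogen on a saturated chain carbon, two bonds along the chain from an amide-type nitrogen in a ring and a carbonyl carbon. For the measured compounds named here, no measured pair shows this change, and the one measured step touches the amine nitrogen in a ring, not the saturated chain carbon, so it offers no direct guide. With nothing pointing either way, no step beyond the scatter is expected. The estimate for compound 3 in this assay is 75%, ranging from 50% to 100%. The expected step is no change at the digits printed from compound 1 to compound 3 (within the scatter).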

Compound 3, a percentage reported as activity, at one dose (the size of the read-out at that dose, not a potency): 25%
For compound 3 the middle estimate is 50 percentage points above the measured one; measured number outside the range, below it.
By their numbers in this assay, from the lowest: compound 3; then compound 1; then compound 2.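

In this assay, the saturated chain carbon, two bonds along the chain from an amide-type nitrogen in a ring and a carbonyl carbon, proves sensitive to a small change: methyl in place of hydrogen there, which also reads as methyl to ethyl, gives a number 50 percentage points lower from compound 1 to compound 3 (beyond the scatter). Among the compounds shown here, this large step is the first measured at this position, whereas the only earlier step, a number 25 percentage points higher from compound 1 to compound 2 (beyond the scatter), was modest and lay at the amine nitrogen in a ring. No available evidence bears on the reason for this result.

On these data alone, whether the same change would lower the number when 4-chlorophenyl sits on the amine nitrogen in a ring remains open. So does the outcome with a longer chain such as propyl, or with a phenyl ring, in place of the ethyl group of compound 3.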